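Cytotoxicity limit in the series and the outlook for compound 4

This account rests on a few compounds, and the source may have more. Where it says the series, first, only, none or still open, it means among the compounds named here.

In an ADME assay on K562 cells (Homo sapiens) for cytotoxicity, with a stated time of 72 h (on this read-out higher numbers stand for weaker inhibition and lower numbers for stronger inhibition), compound 1 `Oc1ccccc1CNc1ncnc2c1ncn2C1CCCCO1` gives > 100000 nM as a limit of the assay and not a number. Compound 2 `COc1ccc(CNc2ncnc3c2ncn3C2CCCCO2)cc1OC` gives > 100000 nM as a limit too. Compound 3 `Oc1ccccc1CNc1ncnc2c1ncn2C1CCCO1` gives > 100000 nM as a limit as well, so no number fixes its place. Within the data shown here, the series so far shows the limit of > 100000 nM in this assay, at which 3 of the 3 values shown sit, and nothing finer.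

Compound 4 `COc1cccc(CNc2ncnc3c2ncn3C2CCCO2)c1` carries 3-methoxyphenyl in place of 2-hydroxyphenyl on a saturated chain carbon bound to a nitrogen on an aromatic ring, and the counted change is 3-methoxyphenyl in place of 2-hydroxyphenyl on a saturated chain carbon bound to a nitrogen on an aromatic ring as computed from the two structures. Among the measured compounds shown here, the only measured step is a step that the two limits leave unreadable from compound 1 to compound 3 with oxolan-2-yl in place of oxan-2-yl on an aromatic nitrogen, so it sits at another place and offers no size to carry over. The expectation leans instead on compound 2 at > 100000 nM as a limit, whose aryl group also bears methoxy and no hydroxy. No step beyond the usual scatter is expected in this assay in either direction. The estimated outcome is a number no higher from compound 3 to compound 4 (the limit leaves the size open) as the expected step. Compound 4 is expected at 100000 nM in an estimated range from 50000 nM to 200000 nM and will probably be reported as a limit again.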

Compound 4, half-maximal inhibitory concentration: > 100000 nM
Compound 4: no number, only a limit; the forecaster's own chance of this, stated with the estimate: 85%; the middle value lies on the limit itself.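

Compound 3 and compound 4 both give only a limit of the assay and not a number in this assay, so no step can be read between them: the limit of > 100000 nM in this assay, at which 4 of the 4 values shown sit.

The compounds shown leave open how any one of them compares with another, and which change on the shared core, if any, would give a number.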